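The compounds below may be only part of what the source reports. "The series", "measured", "known", "first", "only" and "open" are said of these compounds alone.

Of the compounds shown here, three built on the same core have been tested so far in a functional assay on JAR cells (Homo sapiens) for inhibition, read by MTT assay, with a stated time of 72 h, tested at 10 uM; a lower number here means less inhibition, a higher number more inhibition at the concentration tested (going by the name of the read-out). Compound 1, `CCOC(=O)C1=C(Nc2ccccc2)S/C(=C\c2ccc(C(=O)O)cc2)C1=O`, gives 16.8%. Compound 2, `CCOC(=O)C1=C(Nc2ccc(OC)cc2)S/C(=C\c2ccc[nH]2)C1=O`, gives 27.6%. Compound 3, `CCOC(=O)C1=C(Nc2cccc(C(F)(F)F)c2)S/C(=C\c2ccc[nH]2)C1=O`, gives 52.9%. Among these three numbers compound 1 stands lowest: compound 2 is the nearest, higher by an amount beyond the usual scatter, and compound 3 is the furthest, higher by a much larger amount. Compounds 2 and 3 each differ from compound 1 in two places at once, so none of these pairs offers a single clean step.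

Compound 4, `CCOC(=O)C1=C(Nc2ccccc2)S/C(=C\c2cccnc2)C1=O`, has not yet been measured in this assay. It differs from compound 1 in one place: pyridin-3-yl in place of 4-carboxyphenyl on a double-bonded chain carbon bound to a double-bonded ring carbon. Within the data shown here, since no measured pair shows the effect of this change on its own, any expectation rests on the spread of the three numbers above, all of which lie at or above that of compound 1. A modest rise is therefore the most likely outcome, though one that could easily fall within the scatter. The expected step of a number 10.2 percentage points higher from compound 1 to compound 4 (beyond the scatter) is small and upward. Compound 4 is estimated to give 27%, with a likely range from 10% to 48%.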

Compound 4, a percentage reported as inhibition, at one concentration (the size of the read-out at that concentration, not a potency): 32.1%
Compound 4: middle estimate off by 5.1 percentage points, on the low side; measured number inside the range.
By their numbers in this assay, from the lowest: compound 1; then compounds 2 and 4 (each within the scatter of the next); then compound 3.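

In this assay, among these compounds, the swap of pyridin-3-yl in place of 4-carboxyphenyl, on a double-bonded chain carbon bound to a double-bonded ring carbon, gives the first single-change comparison: a number 15.3 percentage points higher from compound 1 to compound 4 (beyond the scatter). This shows that the group at this position can shift the read-out by more than repeat measurements would, and that inhibition at this level does not need the 4-carboxyphenyl group. The swap alters several things together, as the group loses heavy atoms and its hydrogen-bond donor and gains a nitrogen in the ring, and nothing available explains the rise or separates these features.

The compounds shown leave open whether the ring nitrogen matters at all, which a plain phenyl ring at this position would help to settle, and whether its location matters, which pyridin-4-yl would test. They also leave open whether this step holds on other versions of the shared core, and how a group such as an amine or a longer chain would fare at the same position.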